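From isobutylcarbonyl to neopentylcarbonyl: compound 1 to compound 3

The source may report more compounds than this note shows. Statements on the series, on what has been measured and on what is new or still open speak of the compounds shown alone.

Going by the values given here, in an ADME assay on a cell-free system (plasma, Rattus norvegicus) for metabolic stability, read by LC-MS, with a stated time of 60 min, tested at 100 uM (on this read-out lower numbers stand for a less stable compound and higher numbers for a more stable compound), compound 1 (`COc1cc(C(=O)O)ccc1OCCCCOc1ccc(C(=O)CC(C)C)c(O)c1C`) gives 99%, the lower of the two numbers measured so far, and compound 2 (`Cc1c(OCCCCOc2ccc(C(=O)O)cc2Cl)ccc(C(=O)CC(C)C)c1O`) gives 123%. Compound 3 (`COc1cc(C(=O)O)ccc1OCCCCOc1ccc(C(=O)CC(C)(C)C)c(O)c1C`) differs from compound 1 as follows: methyl in place of hydrogen on a saturated chain carbon bound to three saturated chain carbons. In words, it has methyl in place of hydrogen on a saturated chain carbon bound to three saturated chain carbons, turning isobutylcarbonyl into neopentylcarbonyl. Among the compounds with values here, only one measured step is available, a number 24 percentage points higher from compound 1 to compound 2 (beyond the scatter). Within the data shown here, it is chloro in place of methoxy on an aromatic carbon, so it bears only weakly on a change in the saturated chain, and no measured step tests that change directly. No shift beyond the scatter is therefore expected, and the estimated step is a number 1 percentage points higher from compound 1 to compound 3 (within the scatter). For compound 3 the expected value is 100%, with an estimated range of 85% to 118%.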

Compound 3, percent of the compound remaining: 48%
Compound 3: the middle estimate sits 52 percentage points above what was measured; the measured number lies below the stated range.
By their numbers in this assay, from the lowest: compound 3; then compound 1; then compound 2.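

In this assay, the change from isobutylcarbonyl to neopentylcarbonyl gives a number 51 percentage points lower from compound 1 to compound 3 (beyond the scatter), showing that this read-out responds strongly to a single added methyl, one heavy atom, on a saturated chain carbon bound to three saturated chain carbons. Going by these compounds alone, the only earlier step was a change on an aromatic carbon and went towards a more stable compound, whereas this one, in the saturated chain, goes towards a less stable compound. Nothing available here explains the size of this step.

On these data alone, it remains open whether an ethyl or a cyclopropyl group in place of that hydrogen would lower the number as methyl does. Also open, as far as these compounds go, is whether chloro in place of methoxy would still raise the number when neopentylcarbonyl is present.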